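From compound 3 to compound 4: propyl gives way to hydrogen

This account rests on a few compounds, and the source may have more. Where it says the series, first, only, none or still open, it means among the compounds named here.

Of the compounds shown here, three have been measured in a functional assay on A549 cells (Homo sapiens) for antiproliferative activity, read by MTT assay, with a stated time of 72 h; on this read-out higher numbers stand for weaker inhibition and lower numbers for stronger inhibition. Compound 1 (`CCCCCCCCCCCNC[C@@H]1OC[C@H](N)[C@@H]1O`) gives 11100 nM, compound 2 (`CCCCCCCCCCCCNC[C@@H]1OC[C@H](N)[C@H]1O`) gives 41100 nM and compound 3 (`CCCCCCCCCCCCCCNC[C@@H]1OC[C@H](N)[C@H]1O`) gives 20000 nM. Compound 3 thus holds the middle place of the three numbers. Its value lies within the scatter of that of compound 1, and beyond the scatter from that of compound 2.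

The next compound, compound 4 (`CCCCCCCCCCCNC[C@@H]1OC[C@H](N)[C@H]1O`), departs from compound 3 by one change: hydrogen in place of propyl on a saturated chain carbon, ten or more bonds along the chain from an amine nitrogen. That is hydrogen in place of propyl on a saturated chain carbon, ten or more bonds along the chain from an amine nitrogen.

For the measured compounds named here, only one measured step bears on this change. It is a 2.1-fold lower number from compound 2 to compound 3 (0.31 log units; beyond the scatter), a modest step that came with ethyl in place of hydrogen at that kind of place. The change to compound 4 runs the opposite way and removes a larger group, so a move towards a higher number, and so weaker inhibition, is expected. Going by the values given here, no single-place step connects compound 1 to the others, and it does not enter this reasoning.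

The expected step is a 2.5-fold higher number from compound 3 to compound 4 (0.40 log units; beyond the scatter). For compound 4 the estimated value is 50000 nM, with an expected range from 22000 nM to 100000 nM.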

Compound 4, half-maximal inhibitory concentration: 9650 nM
The estimate for compound 4 lay 5.2-fold (0.71 log units) above the measured number; the measured number lies below the stated range.
By their numbers in this assay, from the lowest: compounds 4, 1 and 3 (each within the scatter of the next, the first and the last beyond it); then compound 2.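

In this assay, the chain change does not behave as one steady trend: taking propyl off compound 3 gives a lower number, not a higher one (a 2.1-fold lower number from compound 3 to compound 4 (0.32 log units; beyond the scatter)), and taking methyl off compound 2 does the same (a 4.3-fold lower number from compound 2 to compound 4 (0.63 log units; beyond the scatter)). Together with the earlier step that added ethyl (a 2.1-fold lower number from compound 2 to compound 3 (0.31 log units; beyond the scatter)), this shows that both the shorter and the longer chain give lower numbers than compound 2, so among compounds 2, 3 and 4 the number does not move in a single direction with chain length. Compound 4 also gives the first view of the stereocentre at the saturated ring carbon, where the step (a 1.2-fold lower number from compound 1 to compound 4 (0.06 log units; within the scatter)) lies within the scatter and reads on this one change alone: the fact that compounds 1 and 4 differ only in the configuration as drawn.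

The compounds shown leave open how the number responds to a chain shorter than that of compound 4 or longer than that of compound 3, or to a phenyl group at the chain end. They also leave open whether the stereocentre stays without a step beyond the scatter on the longer chains of compounds 2 and 3.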